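Dropping the Methoxy Group: What Compound 3 Might Show

The compounds below may be only part of what the source reports. "The series", "measured", "known", "first", "only" and "open" are said of these compounds alone.

Compound 1, `Fc1ccc(-c2csc(N/N=C/c3ccc(Cl)cc3Cl)n2)cc1`, gives 95.6% in a functional assay, read by spectrophotometry, with a stated time of 15 min, tested at 100 ug/mL; on this read-out higher numbers stand for a stronger effect at the one concentration tested and lower numbers for a weaker effect. Among the measured compounds shown here, compound 2, `COc1ccc(-c2csc(N/N=C/c3ccc(Cl)cc3Cl)n2)cc1`, gives 87.5% in this assay, and the only measured step between the pair is a number 8.1 percentage points lower from compound 1 to compound 2 (within the scatter). For the measured compounds named here, compound 2 thus stands at the lowest of the two numbers so far, with its nearest neighbour, compound 1, separated from it by a gap that stays within the scatter, so no order between the two can be claimed.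

Compound 3, `Clc1ccc(/C=N/Nc2nc(-c3ccccc3)cs2)c(Cl)c1`, is not yet measured. Its change from compound 2 is hydrogen in place of methoxy on an aromatic carbon. Going by the values given here, the single measured step bears only indirectly on this change: it swaps one small group for another on the same aromatic carbon, and it stayed within the scatter. Among the compounds with values here, no measured step shows what removing the group entirely does. On that basis the step from compound 2 to compound 3 is expected to be small, a number 0.5 percentage points higher from compound 2 to compound 3 (within the scatter), in neither direction beyond the scatter. Compound 3 is therefore estimated at 88% in this assay, with a range from 74% to 97%.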

Compound 3, a percentage reported as inhibition, at one concentration (the size of the read-out at that concentration, not a potency): 87.4%
Beside the measured number, compound 3's estimate is 0.6 percentage points above it; the measured number falls inside the stated range.
By their numbers in this assay, from the lowest: compounds 3, 2 and 1 (each within the scatter of the next).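

In this assay, removing the group altogether, from 4-methoxyphenyl to phenyl, gives a number 0.1 percentage points lower from compound 2 to compound 3 (within the scatter) and leaves the aromatic carbon carrying only hydrogen. Setting hydrogen in place of fluoro on that same carbon gives a number 8.2 percentage points lower from compound 1 to compound 3 (within the scatter) and so adds a second comparison with the unsubstituted phenyl, which the earlier swap of fluoro for methoxy could not provide. With hydrogen, fluoro or methoxy at this place, para to a large group, all three compounds stand within the scatter of one another at the one concentration tested, so among these three the read-out does not call for a substituent there, and nothing available explains this level result.

Whether an amine, a carboxylic acid or a longer chain such as butoxy on this carbon would also stay within the scatter remains open, since fluoro, methoxy and hydrogen are the only groups shown there. Among the compounds shown here, the two chlorine atoms and the shared core are the same in all three compounds, so what changes at those places would do also remains unknown, as does whether the three compounds would differ in strength of effect at any other concentration, since only the one concentration was tested.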